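Chain terminus swap on the spiro amide series

A few compounds are considered here, and "the series" means these few. Any claim that something is new, unique, unknown or untested is made for them only; others in the source may bear on it.

Of the compounds shown here, two of the shared core have been measured in an assay on HEK293 cells for displacement of a labelled ligand from NPC1-like intracellular cholesterol transporter 1 (Homo sapiens); on this read-out lower numbers stand for stronger inhibition and higher numbers for weaker inhibition. Compound 1 `CC(C)(C)OC(=O)NCCCNC(=O)CN1CN(c2ccccc2)C2(CCN(C(=O)c3ccc(C4CCCCC4)cc3)CC2)C1=O` gives 6000 nM and compound 2 `CC(C)(C)OC(=O)NCCCNC(=O)CN1CN(c2ccccc2)C2(CCN(C(=O)c3ccc(C(C)(C)C)cc3)CC2)C1=O` gives 4500 nM. Among the measured compounds shown here, on these two numbers compound 1 stands highest, with compound 2 as its only neighbour; the step of a 1.3-fold lower number from compound 1 to compound 2 (0.12 log units; within the scatter) is within the scatter, so the two values are not ordered. That single step concerns a change on the aromatic carbon, tert-butyl in place of cyclohexyl.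

Compound 3 `COC(=O)CCCNC(=O)CN1CN(c2ccccc2)C2(CCN(C(=O)c3ccc(C4CCCCC4)cc3)CC2)C1=O` is not yet measured. It differs from compound 1 elsewhere: methoxycarbonyl in place of (tert-butoxycarbonyl)amino on a saturated chain carbon, three bonds along the chain from an amide-type nitrogen. For the measured compounds named here, no measured step touches this part of the chain; the only step in hand, from compound 1 to compound 2, alters a different position and offers no guide to direction. The expectation for this assay therefore rests on compound 1 alone, and no step beyond the scatter is assumed in either direction: the estimated step is no change at the digits printed from compound 1 to compound 3 (within the scatter). Compound 3 is estimated at 6000 nM in this assay, within a range of 2000 nM to 18000 nM.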

Compound 3, half-maximal inhibitory concentration: 2500 nM
Compound 3: middle estimate off by 2.4-fold (0.38 log units), on the high side; measured number inside the range.
By their numbers in this assay, from the lowest: compounds 3, 2 and 1 (each within the scatter of the next, the first and the last beyond it).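

Notes on the chain terminus: in this assay this end of the chain is the first place in the series where a single change gives a step beyond the scatter, a 2.4-fold lower number from compound 1 to compound 3 (0.38 log units; beyond the scatter), whereas the change on the aromatic carbon gave a 1.3-fold lower number from compound 1 to compound 2 (0.12 log units; within the scatter), which stays within it. The swap of (tert-butoxycarbonyl)amino for methoxycarbonyl alters several things at once, going from 8 heavy atoms to 4 and from 1 hydrogen-bond donor to 0 while keeping 2 hydrogen-bond acceptors, so this one step cannot assign the shift to any single one of these differences. No supporting data bear on why the number moves at this position.

Still open, on these data alone, is whether a carboxylic acid or a free primary amine at the same chain end would move the number further in either direction, and whether a longer or shorter chain carrying the methoxycarbonyl would hold the step. Also open is whether the step carries over to the tert-butyl partner, compound 2, since the methoxycarbonyl end is shown only with cyclohexyl on the aromatic carbon.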